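The source may hold more compounds than are shown below. What is called first, only, known or untested is meant among the compounds shown, and "the series" means these compounds.

Measured compounds and their values:

Compound 1, `Cn1c(=O)c(=O)n(C2CCCC2)c2nc(N/N=C/c3ccc(Cl)cc3)ncc21`: 8420 nM
Compound 2, `Cn1c(=O)c(=O)n(C2CCCC2)c2nc(N/N=C/c3ccc(S(C)(=O)=O)cc3)ncc21`: 26600 nM
Compound 3, `Cn1c(=O)c(=O)n(C2CCCC2)c2nc(N/N=C/c3ccc(O)c(F)c3)ncc21`: 85200 nM

All three were run in a functional assay on PC-3 cells (Homo sapiens) for antiproliferative activity, read by MTT assay; a higher number here means a weaker inhibitor, a lower number a stronger inhibitor. The shared core is kept throughout; the three differ only in the aryl group on the carbon with a double bond to nitrogen. Compound 3 stands at the highest number of the three: the step is a 10-fold higher number from compound 1 to compound 3 (1.01 log units; beyond the scatter) and a 3.2-fold higher number from compound 2 to compound 3 (0.51 log units; beyond the scatter), both beyond the scatter, so compound 3 is the weakest of the measured set. Compound 1 and compound 2 are separated by a 3.2-fold higher number from compound 1 to compound 2 (0.50 log units; beyond the scatter).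

Compound 4, `COc1ccc(/C=N/Nc2ncc3c(n2)n(C2CCCC2)c(=O)c(=O)n3C)c(OC)c1`, has not yet been measured. Its difference from compound 3 is 2,4-dimethoxyphenyl in place of 3-fluoro-4-hydroxyphenyl on a carbon with a double bond to nitrogen.

Bearing on this are the two steps into compound 3, a 10-fold higher number from compound 1 to compound 3 (1.01 log units; beyond the scatter) and a 3.2-fold higher number from compound 2 to compound 3 (0.51 log units; beyond the scatter), which show that the 3-fluoro-4-hydroxyphenyl group gives higher numbers than either of the other two aryl groups tried. Within the data shown here, no step directly involving a 2,4-dimethoxyphenyl group is known, so the size of the change cannot be anchored closely. Because both a 10-fold higher number from compound 1 to compound 3 (1.01 log units; beyond the scatter) and a 3.2-fold higher number from compound 2 to compound 3 (0.51 log units; beyond the scatter) run toward higher numbers for compound 3, a step back toward lower numbers is expected on replacing that group. Compound 4 is therefore expected at 20000 nM, within 6000 nM to 70000 nM, which corresponds to an expected step of a 4.3-fold lower number from compound 3 to compound 4 (0.63 log units; beyond the scatter).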

Compound 4, half-maximal inhibitory concentration: > 100000 nM
Compound 4 gave a limit, no number; the forecaster's own chance of this, stated with the estimate: 10%; middle value at least 5.0-fold (0.69 log units) from the limit.
By their numbers in this assay, from the lowest: compound 1; then compound 2; then compound 3. At a limit, above all of these: compound 4.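

In this assay compound 4 stands at a limit of the assay and not at a number: the limit of > 100000 nM in this assay, at which 1 of the 4 values shown sits. Replacing the aryl group on the carbon with a double bond to nitrogen by 2,4-dimethoxyphenyl brings no return toward lower numbers, since the steps in from the two lower compounds are an at least 3.7-fold higher number from compound 2 to compound 4 (0.57 log units; beyond the scatter) and an at least 11-fold higher number from compound 1 to compound 4 (1.07 log units; beyond the scatter). Against compound 3, the only reading is a floor, an at least 1.1-fold higher number from compound 3 to compound 4 (0.06 log units; that floor lies within the scatter), so these two cannot be placed in order, and among the four compounds the two aryl groups carrying hydroxy or methoxy both sit at the high end of the series, with 4-chlorophenyl and 4-(methylsulfonyl)phenyl lower.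

As far as these compounds go, how far compound 4 actually lies beyond compound 3 remains open, so the series cannot yet say whether 2,4-dimethoxyphenyl is worse than 3-fluoro-4-hydroxyphenyl or merely comparable. Also open, from the compounds shown here alone, is whether a phenyl ring with no substituent, with a single methoxy group or with a dimethylamino group would fall with compounds 3 and 4 or with compounds 1 and 2.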